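Fluoro for chloro: expected tolerance of compound 4

The source may hold more compounds than are shown below. What is called first, only, known or untested is meant among the compounds shown, and "the series" means these compounds.

Compound 1 `O=C(Nc1cc(-c2ccccn2)n[nH]1)N1CCC(c2ccc(Cl)cc2)CC1` is assessed in an ADME assay on cells (Peritoneal macrophage cell, Mus musculus) for cytotoxicity, read by fluorescence and resazurin assay, with a stated time of 3 days; a lower number here means that less compound is tolerated, a higher number that more compound is tolerated. Compound 1 returns only a limit, > 55000 nM, as shown by the limit of > 55000 nM in this assay, at which 1 of the 3 values shown sits. Compound 2 `COc1ccccc1C(=O)Nc1[nH]nc(-c2ccccn2)c1C1CC1` likewise returns a limit, > 51000 nM. Compound 3 `COc1ccc(C(=O)Nc2cc(-c3ccccn3)n[nH]2)cc1` also returns a limit, > 40300 nM. For the measured compounds named here, every value shown is therefore a limit, so compound 1 stands on no number that would set it apart from the others, and no step between measured compounds can be drawn. Compound 4 `O=C(Nc1cc(-c2ccccn2)n[nH]1)N1CCC(c2ccc(F)cc2)CC1` differs from compound 1 by fluoro in place of chloro on an aromatic carbon. Going by the values given here, with no measured step to guide size or direction, no step beyond the scatter is expected in this assay. The expected step of a number no higher from compound 1 to compound 4 (the limit leaves the size open) is accordingly essentially none. Compound 4 is expected to give 55000 nM, within 40000 nM to 80000 nM, most likely again reported as a limit.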

Compound 4, half-maximal cytotoxic concentration: > 64000 nM
Compound 4 gave a limit, no number; the forecaster's own chance of this, stated with the estimate: 90%; at least 1.1-fold (0.06 log units) between middle value and limit.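

For the compounds shown here, compound 1 and compound 4 both return only limits in this assay, so no step between them can be read. The compounds shown leave open where any actual half-maximal cytotoxic concentration in this series lies.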